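Methoxy for Methyl on a Cytotoxicity-Limited Anilide

The source may report more compounds than this note shows. Statements on the series, on what has been measured and on what is new or still open speak of the compounds shown alone.

Measured compounds:
- compound 1 `Cc1cc(NC(=O)c2ccc(Cl)cc2)ccc1NS(=O)(=O)C(F)(F)F` gives 201000 nM in an ADME assay on HEK293 cells (Homo sapiens) for cytotoxicity, read by MTT assay, with a stated time of 48 h; a higher number here means a weaker inhibitor, a lower number a stronger inhibitor
- compound 2 `Cc1cc(NC(=O)c2ccc(Cl)c([N+](=O)[O-])c2)ccc1NS(=O)(=O)C(F)(F)F` gives > 250000 nM in this assay, a limit of the assay
- compound 3 `COc1cc(NC(=O)c2ccc(C#N)cc2)ccc1NS(C)(=O)=O` gives > 250000 nM in this assay, also a limit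

Compound 2 stands at the limit of this assay, and compound 3 rests at the same limit; only compound 1 yields an actual number. Compound 4 `COc1cc(NC(=O)c2ccc(Cl)c([N+](=O)[O-])c2)ccc1NS(=O)(=O)C(F)(F)F` differs from compound 2 by methoxy in place of methyl on an aromatic carbon. Within the data shown here, the single measured step, an at least 1.2-fold higher number from compound 1 to compound 2 (0.09 log units; that floor lies within the scatter), concerns the nitro group and does not touch the methyl-to-methoxy exchange, so no measured step speaks to the change at hand. Compound 3 carries a methoxy group alongside other differences and sits at the limit, but no single-point comparison connects it to compound 2. With compound 2 already at the limit of > 250000 nM in this assay, at which 2 of the 3 values shown sit, the change is expected to leave compound 4 at or near the limit, that is a step that the limit leaves unreadable from compound 2 to compound 4, with no step beyond the scatter foreseen. Compound 4 is therefore estimated at 300000 nM, in the range 150000 nM to 600000 nM.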

Compound 4, half-maximal inhibitory concentration: > 250000 nM
Compound 4 was reported as a limit; the forecaster's own chance of this, stated with the estimate: 75%; the middle value lies beyond the limit too.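

Compound 2 and compound 4 each rest at a limit of this assay and not at a number, and the step from one to the other cannot be read. The compounds shown leave open whether methoxy in place of methyl changes this reading at all, and in which direction.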